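Expected cytotoxicity after replacing pyrazole with piperazine

A few compounds are considered here, and "the series" means these few. Any claim that something is new, unique, unknown or untested is made for them only; others in the source may bear on it.

Compound 2 `Cn1nccc1-c1ccc2[nH]c(=O)nc(-c3ccccc3)c2c1` gives in an ADME assay on L6 cells (Rattus norvegicus) for cytotoxicity, read by fluorescence and resazurin assay, with a stated time of 72 h (a lower number here means that less compound is needed, a higher number that more compound is needed for the effect), only a limit, > 50000 nM, as recorded in the limit of > 50000 nM in this assay, at which 1 of the 2 values shown sits. Compound 1 `O=c1nc(-c2ccccc2)c2cc(-c3cccc(F)c3)ccc2[nH]1` gives in this assay the value 23000 nM. Going by the values given here, the one measured step, an at least 2.1-fold higher number from compound 1 to compound 2 (0.33 log units; beyond the scatter), alters the same position as the change now considered. Compound 3 `O=c1nc(-c2ccccc2)c2cc(N3CCNCC3)ccc2[nH]1` carries the change (piperazin-1-yl in place of 1-methyl-1H-pyrazol-5-yl on an aromatic carbon). Among the compounds with values here, since no measured compound carries piperazin-1-yl, that step guides only loosely, and no change beyond the scatter is expected in either direction. Compound 3 is estimated at 50000 nM, between 15000 nM and 150000 nM. The expected step is therefore a number no higher from compound 2 to compound 3 (the limit leaves the size open).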

Compound 3, half-maximal effective concentration: > 25000 nM
Compound 3: no number, only a limit (the forecaster's own chance of this, stated with the estimate: 60%); the middle value is on the limit's open side.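

Like the 1-methyl-1H-pyrazol-5-yl group before it, the non-aromatic piperazin-1-yl ring at this position gives compound 3 only a limit in this assay: the limit of > 25000 nM in this assay, at which 1 of the 3 values shown sits.

Set against the 3-fluorophenyl group, the change gives an at least 1.0-fold higher number from compound 1 to compound 3 (0.03 log units; that floor lies within the scatter), so piperazin-1-yl cannot yet be separated from 3-fluorophenyl here. The step between compound 2 and compound 3 cannot be read, as both values are limits.

On these data alone, whether the two limited compounds differ at all stays open. So does what a morpholine ring or a carboxylic acid at this position would give in this assay.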